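Cytotoxicity notes on the bicyclic urea series, compound 2 to 4

The source may report more compounds than this note shows. Statements on the series, on what has been measured and on what is new or still open speak of the compounds shown alone.

For the measured compounds named here, only two numbers are in hand. Compound 2 `O=C1CC(Oc2ncc(F)cn2)CN1c1cnn2c1CN(C(=O)Nc1cc(F)c(F)c(F)c1)C(C1CC1)C2` gives 96200 nM in a toxicity assay on HepG2 2.2.15 cells (Homo sapiens) for cytotoxicity, read by CellTiter-Glo; a higher number here means that more compound is tolerated, a lower number that less compound is tolerated; compound 3 `CC1CN(C(=O)Nc2cc(F)c(F)c(F)c2)Cc2c(N3CC(C#N)CC3=O)cnn21` gives 115000 nM in this assay, and the two sit within the usual scatter of one another, so compound 2 stands level with compound 3 rather than apart from it. Compound 1 `CC1CCn2ncc(N3CC(c4ccccc4)CC3=O)c2CN1C(=O)Nc1cc(F)c(F)c(F)c1` reports only a limit, > 2000 nM, in this assay; (the limit of > 2000 nM in this assay, at which 1 of the 3 values shown sits). Going by the values given here, no measured pair differs in a single place, so no step size is known from the data themselves. Compound 4 `O=C1CC(c2nccs2)CN1c1cnn2c1CN(C(=O)Nc1cc(F)c(F)c(F)c1)C(C1CC1)C2` differs from compound 2 by 1,3-thiazol-2-yl in place of (5-fluoropyrimidin-2-yl)oxy on a saturated ring carbon. Among the compounds with values here, with no measured step to lean on, the expectation for this assay is a step no larger than the scatter, in either direction. Compound 4 is thus estimated at 90000 nM, between 35000 nM and 200000 nM, which means an expected step of a 1.1-fold lower number from compound 2 to compound 4 (0.03 log units; within the scatter).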

Compound 4, half-maximal cytotoxic concentration: 115000 nM
Compound 4: middle estimate off by 1.3-fold (0.11 log units), on the low side; low and high end bracket the measured number.
By their numbers in this assay, from the lowest: compounds 2, 3 and 4 (each within the scatter of the next).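

For the compounds shown here, the first measured change at this position, a saturated ring carbon of the five-membered non-aromatic ring, gives a 1.2-fold higher number from compound 2 to compound 4 (0.08 log units; within the scatter) in this assay. Within this one pair, 1,3-thiazol-2-yl in place of (5-fluoropyrimidin-2-yl)oxy, a swap of a six-membered aromatic ring with its oxygen for a smaller five-membered aromatic ring, leaves the read-out level. No measured property bears on this result.

Still open, from the compounds shown here alone, is whether a primary amine or a carboxylic acid on this ring carbon would stay level with compound 2 and compound 4 in this assay.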